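The source may hold more compounds than are shown below. What is called first, only, known or untested is meant among the compounds shown, and "the series" means these compounds.

Compound 1 `O=C1C(Nc2ccccc2F)=CC(=O)c2c1nc1n2[C@H]2OC[C@@H](O)[C@H]2OC1` carries a (2-fluorophenyl)amino group on the shared core. In a functional assay on MGC-803 cells (Homo sapiens) for inhibition, read by sulforhodamine B assay (a higher number here means a weaker inhibitor, a lower number a stronger inhibitor), compound 1 gives 2000 nM, the higher of the two plain numbers here, while compound 2 `Cc1ccc(NC2=CC(=O)c3nc4n(c3C2=O)[C@H]2OC[C@@H](O)[C@H]2OC4)cc1C` gives 860 nM. Compound 3 `CCCN(CCC)C1=CC(=O)c2nc3n(c2C1=O)[C@H]1OC[C@@H](O)[C@H]1OC3` gives > 16000 nM, which is a limit of the assay rather than a number. The change to compound 4 `O=C1C(NC2CC2)=CC(=O)c2c1nc1n2[C@H]2OC[C@@H](O)[C@H]2OC1` is cyclopropyl in place of 2-fluorophenyl on an amine nitrogen. Among the compounds with values here, the only comparable step, an at least 18-fold higher number from compound 2 to compound 3 (1.26 log units; beyond the scatter), swapped an aromatic amine for a dialkyl amine and weakened inhibition strongly. Compound 4 keeps the amine hydrogen but loses the aromatic ring, so a clear loss of potency is expected, perhaps smaller than that step, estimated as a 4.0-fold higher number from compound 1 to compound 4 (0.60 log units; beyond the scatter). Compound 4 is therefore expected at 8000 nM, between 2500 nM and 25000 nM.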

Compound 4, half-maximal inhibitory concentration: > 4000 nM
Compound 4: a limit, no number (the forecaster's own chance of this, stated with the estimate: 25%); the middle value is on the limit's open side.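

The value for compound 4 is a limit of the assay, not a number. The step reads an at least 2.0-fold higher number from compound 1 to compound 4 (0.30 log units; that floor lies within the scatter), so cyclopropyl on this amine nitrogen shows no gain over 2-fluorophenyl, though the floor alone cannot establish a real loss. Compound 4 keeps the amine hydrogen, yet among the four compounds only those with an aromatic ring on this nitrogen, compound 1 and compound 2, give plain numbers.

Going by these compounds, the true size of the step stays open. So does whether a benzyl or cyclohexyl group on this nitrogen would give a plain number.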